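A few compounds are considered here, and "the series" means these few. Any claim that something is new, unique, unknown or untested is made for them only; others in the source may bear on it.

Among the compounds with values here, in an ADME assay on HeLa cells (Homo sapiens) for cytotoxicity, read by resazurin assay, with a stated time of 2 days (on this read-out higher numbers stand for weaker inhibition and lower numbers for stronger inhibition), compound 1 `Cc1cccc(/C=C/c2ncc([N+](=O)[O-])n2C)c1` gives 30900 nM, the lower of the two numbers so far, while compound 2 `Cn1c([N+](=O)[O-])cnc1/C=C/c1ccccc1Br` gives 72400 nM, a gap beyond the scatter. Compound 3 `COc1cccc(/C=C/c2ncc([N+](=O)[O-])n2C)c1` keeps the core of compound 1 and changes it in one place: methoxy in place of methyl on an aromatic carbon. Within the data shown here, no measured pair shows this change, and no shift beyond the scatter is expected in this assay. The expected change is a 1.3-fold higher number from compound 1 to compound 3 (0.11 log units; within the scatter). The estimated value for compound 3 is 40000 nM, with an expected range of 15000 nM to 100000 nM.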

Compound 3, half-maximal inhibitory concentration: > 100000 nM
Compound 3: no number, only a limit; the forecaster's own chance of this, stated with the estimate: 15%; middle value at least 2.5-fold (0.39 log units) from the limit.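

In this assay, within the data shown here, methoxy in place of methyl on an aromatic carbon, meta to a large group, gives an at least 3.2-fold higher number from compound 1 to compound 3 (0.51 log units; beyond the scatter) and this is the first change at a single place that can be read on the core of compound 1. The earlier compounds shown here offered no such pair. The reading for compound 3 is a limit and not a number, so the step has a lower bound but no measured size: the limit of > 100000 nM in this assay, at which 1 of the 3 values shown sits.

As far as these compounds go, whether ethyl, hydroxyl or an amine at this place would shift the number in the same way remains open. A single pair also cannot show whether the step holds at other places on the ring.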